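Replacing ethyl with chloro on the shared core

The compounds below may be only part of what the source reports. "The series", "measured", "known", "first", "only" and "open" are said of these compounds alone.

In a functional assay on MT2 cells (Homo sapiens) for cytotoxicity (a lower number here means that less compound is tolerated, a higher number that more compound is tolerated), compound 1 `CC(C)=CCOc1cc(Nc2nccs2)ccc1C(C)C` gives 31000 nM, and compound 2 `CCc1ccc(Nc2nccs2)cc1OCC=C(C)C` stands level with it at 31000 nM. Compound 3 `CC(C)=CCOc1cc(Nc2nccs2)ccc1Cl` carries chloro in place of ethyl on an aromatic carbon. For the measured compounds named here, the one measured step that bears on this is no change at the digits printed from compound 1 to compound 2 (within the scatter), a swap of hydrogen in place of methyl on the neighbouring alkyl group's chain, and it stays within the scatter. It offers only indirect guidance for chloro, so no shift beyond the scatter is expected in this assay. The expected step is a 1.1-fold lower number from compound 2 to compound 3 (0.03 log units; within the scatter). For compound 3 the estimated value is 29000 nM, with an expected range of 13000 nM to 65000 nM.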

Compound 3, half-maximal cytotoxic concentration: 26000 nM
For compound 3 the middle estimate is 1.1-fold (0.05 log units) above the measured one; low and high end bracket the measured number.
By their numbers in this assay, from the lowest: compounds 3, 1 and 2 (each within the scatter of the next).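

In this assay, chloro in place of ethyl gives a 1.2-fold lower number from compound 2 to compound 3 (0.08 log units; within the scatter), and chloro in place of isopropyl gives a 1.2-fold lower number from compound 1 to compound 3 (0.08 log units; within the scatter). The earlier compounds shown here carried only alkyl groups at this position, para to a (1,3-thiazol-2-yl)amino group, and a single chlorine atom now reads the same as both within the scatter. Nothing available explains this sameness. The compounds shown leave open whether an amine or a carboxylic acid at this position would shift the number beyond the scatter.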